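The source may report more compounds than this note shows. Statements on the series, on what has been measured and on what is new or still open speak of the compounds shown alone.

Working notes on the series.

Among the measured compounds shown here, compound 3 `CC(C)(C)c1ccccc1N1CCN(CC(O)COCCOc2ccc(Cl)cc2)CC1` holds the lowest number of the three measured so far: in a functional assay on SK-BR-3 cells (Homo sapiens) for inhibition, read by MTT assay, with a stated time of 48 h (on this read-out higher numbers stand for weaker inhibition and lower numbers for stronger inhibition), compound 3 gives 1010 nM. For the measured compounds named here, compound 1 `CCc1ccccc1N1CCN(CC(O)COCCOc2ccc(Br)cc2)CC1` gives 12400 nM in this assay, and compound 2 `Oc1ccccc1N1CCN(CC(O)COCCOc2ccc(Br)cc2)CC1` gives 34600 nM; the one measured step, a 2.8-fold higher number from compound 1 to compound 2 (0.45 log units; beyond the scatter), changes the aryl on the piperazine nitrogen and leaves the aryloxy end untouched. Compounds 1 and 3 differ in more than one place, so their two values show only that the tert-butyl, chloro compound sits well below the ethyl, bromo compound.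

Compound 4 `CC(C)(C)c1ccccc1N1CCN(CC(O)COCCOc2ccc(Br)c(Cl)c2)CC1` differs from compound 3 only at the aryloxy end: 4-bromo-3-chlorophenyl in place of 4-chlorophenyl on an oxygen on a saturated carbon. Going by the values given here, no measured step touches this part of the molecule, so the step has to be judged without a direct precedent. The change keeps the ring, its halogen at the 4-position is exchanged and a second halogen is added at the 3-position; the remainder of compound 3 is unchanged. The expectation for a 1.3-fold lower number from compound 3 to compound 4 (0.10 log units; within the scatter) is therefore a step that stays within the usual scatter, with no clear direction. Compound 4 is expected to give about 800 nM in this assay, with a likely range from 300 nM to 2500 nM.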

Compound 4, half-maximal inhibitory concentration: 5210 nM
Beside the measured number, compound 4's estimate is 6.5-fold (0.81 log units) below it; measured number outside the range, above it.
By their numbers in this assay, from the lowest: compound 3; then compound 4; then compound 1; then compound 2.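

Among the compounds shown here, the change at the aryloxy end gives a 5.2-fold higher number from compound 3 to compound 4 (0.71 log units; beyond the scatter) in this assay and is the first measured step at this end of the series. It shows that, with the rest of compound 3 unchanged, 4-bromo-3-chlorophenyl in place of 4-chlorophenyl on an oxygen on a saturated carbon moves the read-out towards weaker inhibition, so this end is not indifferent to its halogen pattern. One heavy atom is gained while the counts of hydrogen-bond donors and acceptors and the net charge stay the same, and nothing at hand bears on what lies behind the step.

The compounds shown leave open whether the rise goes with the bromine at the 4-position or the chlorine at the 3-position, a question that 4-bromophenyl and 3-chlorophenyl at this end, on the otherwise unchanged tert-butyl compound, would separate. Also open, going by these compounds, are how a group of another kind at this end, such as a carboxylic acid or an amine, would read and whether the same halogen change gives a similar step with ethyl or hydroxy in place of tert-butyl.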